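Replacing the Ethynyl Group with Ethyl on the Amide Carbonyl

The compounds below may be only part of what the source reports. "The series", "measured", "known", "first", "only" and "open" are said of these compounds alone.

Measured compounds:
compound 1, `C=C(C)C(=O)N(Cc1ccc(OC)c(O)c1)c1cc(OC)c(OC)c(OC)c1`, 200 nM
compound 2, `C#CC(=O)N(Cc1ccc(OC)c(O)c1)c1cc(OC)c(OC)c(OC)c1`, 570 nM

In a functional assay on KYSE-450 cells (Homo sapiens) for inhibition, read by MTT assay, with a stated time of 48 h (on this read-out higher numbers stand for weaker inhibition and lower numbers for stronger inhibition), compound 2 gives the highest of the two numbers shown; its nearest neighbour is compound 1, and the step of a 2.9-fold higher number from compound 1 to compound 2 (0.45 log units; beyond the scatter) places compound 2 beyond the scatter from it. Compound 3, `CCC(=O)N(Cc1ccc(OC)c(O)c1)c1cc(OC)c(OC)c(OC)c1`, is not yet measured. It differs from compound 2 in one place, (ethyl in place of ethynyl on a carbonyl carbon), where ethyl replaces ethynyl on the carbonyl carbon. Among the compounds with values here, the only measured step, a 2.9-fold higher number from compound 1 to compound 2 (0.45 log units; beyond the scatter), compares two different unsaturated groups at this carbonyl and so bears only loosely on a change to ethyl; no measured pair shows what removing the triple bond does. Compound 3 is therefore expected to give a step of a 2.6-fold higher number from compound 2 to compound 3 (0.42 log units; beyond the scatter) in this assay, with wide uncertainty. The estimated value for compound 3 is 1500 nM, within the range 400 nM to 6000 nM.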

Compound 3, half-maximal inhibitory concentration: 98 nM
Compound 3: middle estimate off by 15-fold (1.18 log units), on the high side; the measured number lies below the stated range.
By their numbers in this assay, from the lowest: compound 3; then compound 1; then compound 2.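

In this assay, a triple bond is not needed on this carbonyl carbon: the change gives a 5.8-fold lower number from compound 2 to compound 3 (0.76 log units; beyond the scatter), and replacing 1-methylethenyl with ethyl gives a 2.0-fold lower number from compound 1 to compound 3 (0.31 log units; beyond the scatter). Both steps lie beyond the scatter, so of these three compounds the one with the plain ethyl group, compound 3, gives the lowest number, and neither unsaturated group matches it. Ethyl and ethynyl have the same heavy-atom count, so the first step follows a change in bonding at this place and not in the count of heavy atoms, but nothing available explains why the number falls.

The compounds shown leave open whether a methyl group, a longer chain such as propyl, or a cyclopropyl ring on this carbonyl carbon would lower the number further. They also leave open whether the same order holds in any other cell line.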